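The source may hold more compounds than are shown below. What is called first, only, known or untested is meant among the compounds shown, and "the series" means these compounds.

Working notes on the thiazolidinedione series.

Compound 2 `Cc1ncsc1CCOc1ccc(/C=C2\SC(=O)NC2=O)cc1Cl` gives 5170 nM in an assay for inhibition of 15-hydroxyprostaglandin dehydrogenase [NAD(+)] (Homo sapiens), read by fluorescence and spectrophotometry (a higher number here means a weaker inhibitor, a lower number a stronger inhibitor), the highest of the three numbers measured. Compound 1 `O=C1NC(=O)/C(=C/c2ccc(OCc3ccc([N+](=O)[O-])cc3)cc2Cl)S1` sits nearest to it at 4540 nM, within the scatter, so no order can be read between compound 1 and compound 2. Going by the values given here, compound 3 `O=C1NC(=O)/C(=C/c2ccc(OC(=O)c3cccs3)c(Cl)c2)S1` gives 264 nM, and the step of a 20-fold lower number from compound 2 to compound 3 (1.29 log units; beyond the scatter) is the only change of the side chain on the aromatic oxygen measured so far.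

Compound 4 `O=C1NC(=O)/C(=C/c2ccc(OCCOC3CCCCC3)c(Cl)c2)S1` has not yet been measured in this assay. It differs from compound 2 in the same region of the molecule: cyclohexyloxy in place of 4-methyl-1,3-thiazol-5-yl on a saturated chain carbon, two bonds along the chain from an oxygen on an aromatic ring. The step from compound 2 to compound 3 bears on it only loosely, since there the whole chain was exchanged for a carbonyl-linked group, whereas in compound 4 the chain is kept and only its terminal group is replaced. Compound 1 and compound 2, both carrying a chain from the aromatic oxygen to a ring, fall within the scatter of each other, which argues for a small step here.

For compound 4 a step of a 1.5-fold lower number from compound 2 to compound 4 (0.17 log units; within the scatter) is expected, toward a somewhat lower number but possibly not beyond the scatter. The estimate for compound 4 in this assay is 3500 nM, with a range from 1200 nM to 11000 nM.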

Compound 4, half-maximal inhibitory concentration: 20 nM
Estimate against measurement, compound 4: 180-fold (2.24 log units) above; the whole stated range lies above it.
By their numbers in this assay, from the lowest: compound 4; then compound 3; then compounds 1 and 2 (each within the scatter of the next).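

In this assay, the chain on an oxygen on an aromatic ring is kept and only its terminal group changes, yet the result is a 260-fold lower number from compound 2 to compound 4 (2.41 log units; beyond the scatter). The terminal group is therefore no minor detail at this position: cyclohexyloxy in place of 4-methyl-1,3-thiazol-5-yl carries a large step on its own, which the exchange of the whole chain in compound 3 could not show. No measured evidence accounts for the size of this step. The compounds shown leave open whether the lower number follows the ether oxygen of cyclohexyloxy or the saturated carbon ring, a separation that a plain cyclohexyl group on the same chain would provide. Also open, on these data alone, is how a phenoxy group, a piperidin-1-yl group or a longer chain would read at this place.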